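Chloro to methyl on a fused core: an expected loss

The source may hold more compounds than are shown below. What is called first, only, known or untested is meant among the compounds shown, and "the series" means these compounds.

Three compounds have been measured in an assay on isolated protein for inhibition of complement C1r subcomponent (Homo sapiens); a lower number here means a stronger inhibitor, a higher number a weaker inhibitor:
Compound 1, `O=c1oc(Nc2ccccc2I)nc2ccc(Cl)cc12`, gives 4000 nM.
Compound 2, `O=c1oc(Nc2ccccc2I)nc2cc(Cl)ccc12`, gives 700 nM.
Compound 3, `Cc1ccc2nc(Nc3ccccc3I)oc(=O)c2c1`, gives only a limit of the assay, > 62500 nM.

Compound 1 and compound 3 differ in one place: methyl in place of chloro on an aromatic carbon. This change produced an at least 15-fold higher number from compound 1 to compound 3 (1.19 log units; beyond the scatter). For compound 3 the reading is the limit of > 62500 nM in this assay, at which 1 of the 3 values shown sits. Compound 2 has the same atoms as compound 1 joined differently; the difference between the two cores is not broken down here. Among the numbers so far, compound 2 gives the lowest, and compound 1 sits at a higher one.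

Compound 4, `Cc1ccc2c(=O)oc(Nc3ccccc3I)nc2c1`, has not yet been measured. It differs from compound 2 by the same change: methyl in place of chloro on an aromatic carbon. Compound 4 is therefore expected to give a higher number in this assay, by about a 29-fold higher number from compound 2 to compound 4 (1.46 log units; beyond the scatter), an expectation that rests on an at least 15-fold higher number from compound 1 to compound 3 (1.19 log units; beyond the scatter). The estimate for compound 4 is 20000 nM, within 5000 nM to 80000 nM, with a real chance that the assay again reports only a limit.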

Compound 4, half-maximal inhibitory concentration: 800 nM
Compound 4: the middle estimate sits 25-fold (1.40 log units) above what was measured; the whole stated range lies above it.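

In this assay, methyl in place of chloro on the core of compound 2 gives a 1.1-fold higher number from compound 2 to compound 4 (0.06 log units; within the scatter), so on this core the two groups cannot be told apart. The step does not carry over from one core to the other at the same size: the same change on two cores in this assay, an at least 15-fold higher number (1.19 log units; beyond the scatter) from compound 1 to compound 3 and a 1.1-fold higher number (0.06 log units; within the scatter) from compound 2 to compound 4, at least 13-fold (1.13 log units) apart, beyond the scatter of two such steps. Compound 3 gives only a limit, > 62500 nM, so the full size of the earlier step stays unknown, and two cores cannot show why the same change reads so differently or what it would do on a third core.

The compounds shown leave open how other groups in this place, such as an amine, a methoxy group or a carboxylic acid, would read on either core. They also leave open whether the core of compound 2 would again make little of such a swap, or whether the match between chloro and methyl holds only for this one pair.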